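Halogen swap on the shared core: compound 3 to compound 4

The compounds below may be only part of what the source reports. "The series", "measured", "known", "first", "only" and "open" are said of these compounds alone.

Compound 3 `Nc1nc(N)nc(-c2ccc(Cl)cc2Br)n1` stands highest of the three measured in a functional assay on the whole organism with Rattus norvegicus as the target, at a dose of 20 mg/kg by the intraperitoneal route; on this read-out lower numbers stand for less inhibition and higher numbers for more inhibition at the one dose given (going by the name of the read-out): compound 3 gives 96%, against compound 2 `Nc1nc(N)nc(-c2cc(C(F)(F)F)ccc2Cl)n1` with 51% and compound 1 `Nc1nc(N)nc(-c2ccccc2Br)n1` with 26%. Compound 4 `Nc1nc(N)nc(-c2ccc(Cl)cc2Cl)n1` differs from compound 3 by chloro in place of bromo on an aromatic carbon. Within the data shown here, no measured pair shows an exchange of bromo for chloro; the one measured step, a number 70 percentage points higher from compound 1 to compound 3 (beyond the scatter), concerns chloro in place of hydrogen and so bears on the present change only indirectly, showing that the halogen pattern on this ring moves the read-out strongly. For compound 4 a small downward step from compound 3 is expected, a number 11 percentage points lower from compound 3 to compound 4 (beyond the scatter), within the usual scatter. Compound 4 is therefore estimated at 85% in this assay, ranging from 60% to 98%.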

Compound 4, a percentage reported as inhibition, in the whole organism at one dose (the size of the read-out at that dose, not a potency) in the Rattus norvegicus assay: 100%
Compound 4: middle estimate off by 15 percentage points, on the low side, outside the stated range (above it).
By their numbers in the Rattus norvegicus assay, from the lowest: compound 1; then compound 2; then compounds 3 and 4 (each within the scatter of the next).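

In the Rattus norvegicus assay, chloro in place of bromo on this aromatic carbon gives a number 4 percentage points higher from compound 3 to compound 4 (within the scatter), so the two halogens are not separated at this position, which the earlier chloro-for-hydrogen step could not show. In a physicochemical assay for lipophilicity (on this read-out lower numbers stand for lower lipophilicity and higher numbers for higher lipophilicity), compound 3 gives 2.09 and compound 4 gives 2.07, which are also within the scatter of each other. No supporting data on the origin of these results are available.

Open, from the compounds shown here alone, is how the Rattus norvegicus assay responds at this position to a group other than a halogen, such as a methoxy group or an amine.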